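This account rests on a few compounds, and the source may have more. Where it says the series, first, only, none or still open, it means among the compounds named here.

Within the data shown here, compound 2 `CCNC(=O)c1cc(N)c(Nc2ccc(C#N)cc2)cc1Oc1c(C)cc(CCC#N)cc1C` gives 3.63 in a physicochemical assay for lipophilicity, read by HPLC, measured as octanol-water partition, with a stated time of 24 h, at pH 7.4 (on this read-out lower numbers stand for lower lipophilicity and higher numbers for higher lipophilicity), the higher of the two numbers so far; compound 1 `Cc1cc(CCC#N)cc(C)c1Oc1cc(Nc2ccc(C#N)cc2)c(N)cc1C(=O)N(C)C` gives 2.86 in this assay. Among the measured compounds shown here, the one measured step is a number 0.77 log units higher from compound 1 to compound 2 (beyond the scatter). Compound 3 `Cc1cc(CCC#N)cc(C)c1Oc1cc(Nc2ccc(C#N)cc2)c(N)cc1C(=O)NC1CC1` differs from compound 2 by cyclopropyl in place of ethyl on an amide-type nitrogen. For the measured compounds named here, no measured step replaces an alkyl with a carbocycle on that nitrogen; the step from compound 1 to compound 2 touches the same nitrogen but is a change of another kind, so it offers only loose guidance toward a small rise or none. Compound 3 is expected to come in at 3.75, range 3.4 to 4.1, a step of a number 0.12 log units higher from compound 2 to compound 3 (within the scatter) that may stay within the scatter.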

Compound 3, partition coefficient: 2.61
Beside the measured number, compound 3's estimate is 1.14 log units above it; measured number outside the range, below it.
By their numbers in this assay, from the lowest: compounds 3 and 1 (each within the scatter of the next); then compound 2.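

In this assay, cyclopropyl in place of ethyl on an amide-type nitrogen gives a number 1.02 log units lower from compound 2 to compound 3 (beyond the scatter), so at this position the outcome does not follow heavy-atom count, with 3 in cyclopropyl against 2 in ethyl. The remaining pair shows a number 0.25 log units lower from compound 1 to compound 3 (within the scatter), which leaves compound 2 alone at the high end of these three compounds. Nothing available explains the drop from ethyl to cyclopropyl.

Open, from the compounds shown here alone, is whether a propyl chain or a cyclobutyl ring on that nitrogen would track ethyl or cyclopropyl. Also open, going by these compounds, is whether this step holds on other cores.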